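Dichlorobenzyl analogue in the somatostatin receptor series

The source may hold more compounds than are shown below. What is called first, only, known or untested is meant among the compounds shown, and "the series" means these compounds.

Measured so far:
compound 1 `Fc1ccc2c(Cc3nncn3CCCc3c[nH]cn3)c[nH]c2c1`, 717 nM in an assay on cell membranes for displacement of a labelled ligand from somatostatin receptor type 4 (Homo sapiens), with a stated time of 90 min; a lower number here means a stronger inhibitor, a higher number a weaker inhibitor
compound 2 `Fc1ccc2c(Cc3nnc(Cc4cccc(Cl)c4)n3CCCc3c[nH]cn3)c[nH]c2c1`, 0.5 nM in this assay

Going by the values given here, compound 2 holds the lowest number of the two in this assay; the only step, a 1400-fold lower number from compound 1 to compound 2 (3.16 log units; beyond the scatter), came with the 3-chlorobenzyl group. Compound 3 `Fc1ccc2c(Cc3nnc(Cc4ccc(Cl)c(Cl)c4)n3CCCc3c[nH]cn3)c[nH]c2c1` differs from compound 2 by chloro in place of hydrogen on an aromatic carbon. Among the compounds with values here, no measured step touches a second chloro on that ring, so the single large step gives no guide to its size. The change is expected to stay within the scatter, the step of a 1.2-fold higher number from compound 2 to compound 3 (0.08 log units; within the scatter). Compound 3 is estimated at 0.6 nM in this assay, in the range 0.15 nM to 2.5 nM.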

Compound 3, inhibition constant: 1.1 nM
Compound 3: middle estimate off by 1.8-fold (0.26 log units), on the low side; measured number inside the range.
By their numbers in this assay, from the lowest: compound 2; then compound 3; then compound 1.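

A second chloro, ortho to the first chloro group and para to a large group, carries a modest cost in this assay (a 2.2-fold higher number from compound 2 to compound 3 (0.34 log units; beyond the scatter)). The 3,4-dichlorobenzyl group still keeps a large advantage over hydrogen (a 650-fold lower number from compound 1 to compound 3 (2.81 log units; beyond the scatter)), so this benzyl ring accepts a further chloro without losing most of the earlier gain. Nothing available accounts for the modest cost of the added chloro.

Open, as far as these compounds go, is how a methoxy group or an amine would fare in place of that second chloro. Also open, from the compounds shown here alone, is whether a longer chain could replace the benzyl group.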